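Distal aryl substituent exchange in a furan acid series

The compounds below may be only part of what the source reports. "The series", "measured", "known", "first", "only" and "open" are said of these compounds alone.

Compound 2 `Cc1oc(C(=O)O)cc1COc1ccc(-c2ccc(C#N)cc2)cc1` gives 1500 nM in an assay on cells for displacement of a labelled ligand from prostaglandin E2 receptor EP4 subtype (Homo sapiens), read by scintillation counting; on this read-out lower numbers stand for stronger inhibition and higher numbers for weaker inhibition. Among the three measured compounds it holds the second highest number: compound 1 `COc1ccccc1-c1ccc(OCc2cc(C(=O)O)oc2C)cc1` with 1600 nM is nearest, a 1.1-fold lower number from compound 1 to compound 2 (0.03 log units; within the scatter), and compound 3 `COc1ccc(-c2ccc(OCc3cc(C(=O)O)oc3C)cc2)nc1` with 1300 nM is furthest, a 1.2-fold lower number from compound 2 to compound 3 (0.06 log units; within the scatter). Compound 1 and compound 3 are themselves separated only by a 1.2-fold lower number from compound 1 to compound 3 (0.09 log units; within the scatter). All three share the same core and differ only in the aryl group attached to it, and no exchange of that group has so far moved the number beyond the scatter.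

Compound 4 `Cc1oc(C(=O)O)cc1COc1ccc(-c2ccc(S(C)(=O)=O)cc2)cc1` continues this line: methylsulfonyl in place of cyano on an aromatic carbon. The measured steps that bear on this change are the three earlier exchanges of the same aryl group, a 1.1-fold lower number from compound 1 to compound 2 (0.03 log units; within the scatter), a 1.2-fold lower number from compound 1 to compound 3 (0.09 log units; within the scatter) and a 1.2-fold lower number from compound 2 to compound 3 (0.06 log units; within the scatter), each within the scatter. Three exchanges of this kind with no measurable effect give no basis to expect that a fourth will behave differently. The expectation for compound 4 in this assay is therefore no step beyond the scatter, no change at the digits printed from compound 2 to compound 4 (within the scatter). Compound 4 is estimated at 1500 nM, with a range from 600 nM to 3800 nM.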

Compound 4, inhibition constant: > 10000 nM
Compound 4: only a limit was reported; the forecaster's own chance of this, stated with the estimate: 5%; middle value at least 6.6-fold (0.82 log units) away from the limit.
By their numbers in this assay, from the lowest: compounds 3, 2 and 1 (each within the scatter of the next). At a limit, above all of these: compound 4.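

Methylsulfonyl in place of cyano, on an aromatic carbon para to a large group, gives an at least 6.6-fold higher number from compound 2 to compound 4 (0.82 log units; beyond the scatter) in this assay, the only step shown at this position that lies beyond the scatter. Compound 4 gives > 10000 nM, a limit of the assay and not a number. The position is therefore not indifferent to what it carries: compounds 1, 2 and 3 remain within the scatter of one another, yet this single exchange on the distal aryl group separates compound 4 from compound 2, and the reading rests on one compound at the limit: the limit of > 10000 nM in this assay, at which 1 of the 4 values shown sits.

The compounds shown leave open whether the change in the number follows methylsulfonyl specifically or applies more widely to groups with more heavy atoms or hydrogen-bond acceptors than cyano at this place, and a methylthio group or a sulfonamide at the same carbon would bear on that. Also open, going by these compounds, is whether the same exchange has the same effect when the carboxylic acid or another part of the shared core is changed.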